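The source may report more compounds than this note shows. Statements on the series, on what has been measured and on what is new or still open speak of the compounds shown alone.

Measured in a functional assay on QGY-7703 cells (Homo sapiens) for cytotoxicity, read by MTT assay, with a stated time of 24 h; a higher number here means a weaker inhibitor, a lower number a stronger inhibitor:
- compound 1 `CN1C/C(=C\c2cccnc2)C(=O)/C(=C/c2cc([N+](=O)[O-])ccc2F)C1`: 11100 nM
- compound 2 `O=C1/C(=C/c2cccnc2)CN(S(=O)(=O)c2ccc([N+](=O)[O-])cc2)C/C1=C\c1ccccc1F`: 5600 nM

Compound 2, at 5600 nM, lies within the usual scatter of compound 1, at 11100 nM, so these two numbers do not separate the pair. Within the data shown here, the two compounds also differ in more than one place, which means that the data contain no measured single-place step to serve as a guide.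

The account now turns to compound 3 `O=C1/C(=C/c2cccnc2)CN(S(=O)(=O)c2ccc(Br)cc2)C/C1=C\c1ccccc1F`, which keeps the rest of compound 2 and changes one group (bromo in place of nitro on an aromatic carbon). The exchange sits para to a large group and turns the 4-nitrophenyl into a 4-bromophenyl.

Among the measured compounds shown here, with no measured precedent for this exchange, the expectation stays close to compound 2 at 5600 nM, and no clear direction is foreseen. The expected change is a 1.1-fold lower number from compound 2 to compound 3 (0.05 log units; within the scatter), an estimated step that does not go beyond the scatter. In this assay, compound 3 is estimated at 5000 nM, with an expected range from 1900 nM to 13000 nM.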

Compound 3, half-maximal inhibitory concentration: 12800 nM
Compound 3: middle estimate off by 2.6-fold (0.41 log units), on the low side, within the range that was stated.
By their numbers in this assay, from the lowest: compounds 2, 1 and 3 (each within the scatter of the next, the first and the last beyond it).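

In this assay, bromo in place of nitro on an aromatic carbon gives a 2.3-fold higher number from compound 2 to compound 3 (0.36 log units; beyond the scatter). Among these compounds, this is the first step that can be read in one place, and it shows that the number responds to the group at this position, with the 4-nitrophenyl of compound 2 giving the lower number of the two and the 4-bromophenyl of compound 3 the higher. The step is modest and rests on a single pair, so it holds only with the rest of compound 2 kept in place, and nothing in the data available accounts for the size or direction of this shift.

One pair cannot tell whether the number follows the nitro group that leaves or the bromo group that enters, and a 4-aminophenyl, a 4-carboxyphenyl or a plain phenyl at the same position would help separate the two readings. On these data alone, it also remains open whether the same exchange would give a step of similar size on the rest of compound 1, which differs from compound 2 in more than one place.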